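A few compounds are considered here, and "the series" means these few. Any claim that something is new, unique, unknown or untested is made for them only; others in the source may bear on it.

In a functional assay on HL-60 cells (Homo sapiens) for cytotoxicity, read by CCK-8 assay, with a stated time of 72 h (on this read-out higher numbers stand for weaker inhibition and lower numbers for stronger inhibition), compound 3 `C=CCn1c(=O)/c(=C\c2ccc(Cl)c(Cl)c2)[nH]c(=O)/c1=C\c1ccccc1OC` was reported only as "not active" (no number reported), with no number attached, so it stands apart from compound 1 `C=CCn1c(=O)/c(=C\c2cccc(Cl)c2)[nH]c(=O)/c1=C\c1ccccc1OC`, which gives 4500 nM, and from compound 2 `C=CCn1c(=O)/c(=C\c2cccc(Cl)c2Cl)[nH]c(=O)/c1=C\c1ccccc1OC`, which gives 2000 nM. Going by the values given here, the only measured step, a 2.3-fold lower number from compound 1 to compound 2 (0.35 log units; beyond the scatter), concerns chloro in place of hydrogen on an aromatic carbon and does not directly cover the change toward compound 4 `C=CCn1c(=O)/c(=C\c2cccc(Br)c2)[nH]c(=O)/c1=C\c1ccccc1OC`, which is 3-bromophenyl in place of 3,4-dichlorophenyl on a double-bonded chain carbon bound to an aromatic carbon. Compound 4 thus differs from compound 1 only by bromine in place of chlorine, so its potency in this assay is expected to lie near that of compound 1 rather than near the inactivity of compound 3. Compound 4 is estimated to give 4000 nM, with a likely range from 1500 nM to 12000 nM.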

Compound 4, half-maximal inhibitory concentration: 5200 nM
Compound 4: middle estimate off by 1.3-fold (0.11 log units), on the low side, and the stated range covers the measured number.
By their numbers in this assay, from the lowest: compound 2; then compounds 1 and 4 (each within the scatter of the next).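

In this assay compound 4 shows that a single bromine on the 3-bromophenyl group gives a measurable number, whereas the 3,4-dichlorophenyl group of compound 3 was reported only as not active. Bromo in place of chloro on an aromatic carbon brings a 1.2-fold higher number from compound 1 to compound 4 (0.06 log units; within the scatter) and so no readable change, while 3-bromophenyl in place of 2,3-dichlorophenyl brings a 2.6-fold higher number from compound 2 to compound 4 (0.41 log units; beyond the scatter) and loses ground. Nothing given here explains these differences. The compounds shown leave open how this position would respond to a group other than a halogen, such as an amine or a carboxylic acid on the aromatic ring.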